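A few compounds are considered here, and "the series" means these few. Any claim that something is new, unique, unknown or untested is made for them only; others in the source may bear on it.

Compound 3, with the structure `CCn1c(C(=O)N(C)CCC#N)ccc1C(CC)(CC)c1ccc(OCC(O)C(C)(C)C)c(C)c1`, sits second highest among the three measured compounds in an assay on HL-60 cells for agonist activity at vitamin D3 receptor (Homo sapiens), read by microscopy, with a stated time of 96 h (on this read-out lower numbers stand for an effect already at smaller amounts and higher numbers for an effect only at larger amounts of compound), where it gives 1960 nM. Compound 1, with the structure `CC[C@@H](C)[C@H](NC(=O)c1ccc(C(CC)(CC)c2ccc(OCC(=O)C(C)(C)C)c(C)c2)n1CC)C(=O)OC`, gives 590 nM in this assay, a lower number than compound 3, while compound 2, with the structure `CCn1c(C(=O)N(C)CCC#N)ccc1C(CC)(CC)c1ccc(OCC(=O)C(C)(C)C)c(C)c1`, gives 9800 nM, the highest of the three; the change from the ketone to the alcohol accounts for a 5.0-fold lower number from compound 2 to compound 3 (0.70 log units; beyond the scatter). Compound 4, with the structure `CCOc1ccc(NC(=O)c2ccc(C(CC)(CC)c3ccc(OCC(O)C(C)(C)C)c(C)c3)n2CC)cc1`, differs from compound 3 in one place: (4-ethoxyphenyl)amino in place of (2-cyanoethyl)(methyl)amino on a carbonyl carbon. For the measured compounds named here, the only measured step that touches the same carbonyl carbon is a 17-fold higher number from compound 1 to compound 2 (1.22 log units; beyond the scatter), a large step in which (2-cyanoethyl)(methyl)amino replaced another amine and the number rose sharply. Since compound 4 again removes (2-cyanoethyl)(methyl)amino, an expected step downward of clearly more than the scatter seems reasonable, so compound 4 is estimated at 300 nM, in the range 60 nM to 1500 nM, which means an expected change of a 6.5-fold lower number from compound 3 to compound 4 (0.82 log units; beyond the scatter). This expectation rests on a single measured step and carries considerable uncertainty.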

Compound 4, half-maximal effective concentration: 630 nM
Compound 4: the middle estimate sits 2.1-fold (0.32 log units) below what was measured, within the range that was stated.
By their numbers in this assay, from the lowest: compounds 1 and 4 (each within the scatter of the next); then compound 3; then compound 2.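

In this assay, a 3.1-fold lower number from compound 3 to compound 4 (0.49 log units; beyond the scatter) shows that this carbonyl carbon still responds to its amine when the side chain carries the alcohol rather than the ketone. Together with a 17-fold higher number from compound 1 to compound 2 (1.22 log units; beyond the scatter), it gives two single-place pairs, one with each side chain, and in both the compound bearing (2-cyanoethyl)(methyl)amino has the higher number. The compounds shown offer no explanation for either step.

The change to (4-ethoxyphenyl)amino brings in an aromatic ring, an ether oxygen and an amide hydrogen at once, and these compounds cannot separate them; a plain phenylamino or a simple methylamino group on the same carbonyl carbon would begin to do so. Going by these compounds, it also remains open whether (4-ethoxyphenyl)amino would give a step of similar size with the ketone side chain.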